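A Smaller Sulfonyl Substituent on the Shared Core

The source may hold more compounds than are shown below. What is called first, only, known or untested is meant among the compounds shown, and "the series" means these compounds.

For the measured compounds named here, compound 1 `Cc1nc(C)c(CN2CCN(S(=O)(=O)c3ccccc3)CC2)nc1C` is the only member of this set with a number: in a functional assay on ECV-304 cells (Homo sapiens), with stated times of 30 min and 6 h (a lower number here means that less compound is needed, a higher number that more compound is needed for the effect), compound 1 gives 480000 nM. Compound 2 `Cc1ccc(S(=O)(=O)N2CCN(Cc3nc(C)c(C)nc3C)CC2)cc1` carries a 4-methylphenyl on the sulfonyl sulfur; in this assay compound 2 gives "not determined" (no result reported), so no number places it. Compound 3 `Cc1nc(C)c(CN2CCN(S(C)(=O)=O)CC2)nc1C` differs from compound 2 by methyl in place of 4-methylphenyl on a sulfonyl sulfur. Going by the values given here, with no measured step of this kind on the shared core, the size and direction of the change cannot be read from the data. Since compound 1 stands weak at 480000 nM, compound 3 is expected to remain weak, estimated near 500000 nM, between 150000 nM and 2000000 nM.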

Compound 3, half-maximal effective concentration: 162000 nM
Estimate against measurement, compound 3: 3.1-fold (0.49 log units) above; the measured number falls inside the stated range.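

In this assay, for the compounds shown here, methyl in place of phenyl on a sulfonyl sulfur gives a 3.0-fold lower number from compound 1 to compound 3 (0.47 log units; beyond the scatter) and so provides the first measured change at this position, one that lies beyond the scatter. On the shared core, the aromatic ring on the sulfonyl sulfur is therefore not needed for the effect, and the smaller group goes with the lower number in this single pair. The change from 4-methylphenyl in compound 2 cannot be read. Whether a propyl chain or an amine on the sulfonyl sulfur would lower the number further stays open, and nothing in the data shown accounts for the step.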